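Indol-5-yl for quinolin-3-yl on the amine of compound 1

This account rests on a few compounds, and the source may have more. Where it says the series, first, only, none or still open, it means among the compounds named here.

Compound 1 `O=C(/C=C\Nc1cnc2ccccc2c1)c1nc(-c2ccc(C(F)(F)F)cc2)n2ccccc12` sits at a limit of the read-out: in a functional assay on BT-474 cells (Homo sapiens) for cytotoxicity, read by MTT assay, with a stated time of 48 h (on this read-out higher numbers stand for weaker inhibition and lower numbers for stronger inhibition), compound 1 gives > 30000 nM, a limit and not a number. Compound 3 `O=C(/C=C\Nc1cnc2ccccc2c1)c1nc(-c2ccccc2)n2ccccc12` gives 19700 nM in this assay, and compound 2 `O=C(/C=C\Nc1ccc(Cl)cc1)c1nc(-c2ccc(F)cc2)n2ccccc12` gives 7030 nM. Among the compounds with values here, the one measured step, an at least 1.5-fold lower number from compound 1 to compound 3 (0.18 log units; that floor lies within the scatter), touches the trifluoromethyl and not the amine nitrogen. Compound 4 `O=C(/C=C\Nc1ccc2[nH]ccc2c1)c1nc(-c2ccc(C(F)(F)F)cc2)n2ccccc12` differs from compound 1 by 1H-indol-5-yl in place of quinolin-3-yl on an amine nitrogen. Within the data shown here, no measured step bears on this change; compound 2 differs from compound 1 in two places at once, so its value shows only where it stands. No step beyond the scatter is therefore expected in this assay, and with compound 1 at the limit of > 30000 nM in this assay, at which 1 of the 3 values shown sits, the expected step of an at least 1.2-fold lower number from compound 1 to compound 4 (0.07 log units; that floor lies within the scatter) stays uncertain. Compound 4 is expected at 25000 nM, within 8000 nM to 60000 nM.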

Compound 4, half-maximal inhibitory concentration: 5190 nM
The estimate for compound 4 lay 4.8-fold (0.68 log units) above the measured number; measured number below the stated range.
By their numbers in this assay, from the lowest: compounds 4 and 2 (each within the scatter of the next); then compound 3. At a limit, above all of these: compound 1.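

At the amine nitrogen, 1H-indol-5-yl in place of quinolin-3-yl gives an at least 5.7-fold lower number from compound 1 to compound 4 (0.76 log units; beyond the scatter) in this assay, the first step read at this place and the first in the series beyond the scatter. Compound 1 stands at a limit, so this step is a floor and its full size stays unread: the limit of > 30000 nM in this assay, at which 1 of the 4 values shown sits.

On these data alone, whether the step depends on the hydrogen on the indole nitrogen stays open, and a 1-methylindol-5-yl group on the amine would test this. Also open, as far as these compounds go, is whether the same change holds with hydrogen in place of trifluoromethyl.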